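Swapping the nitrile-bearing ring for an aminopyridine

The source may report more compounds than this note shows. Statements on the series, on what has been measured and on what is new or still open speak of the compounds shown alone.

In an in vitro assay on HEK385-7 cells for displacement of a labelled ligand from prostaglandin D2 receptor 2 (Homo sapiens) (a lower number here means a stronger inhibitor, a higher number a weaker inhibitor), three analogues sharing one core have been measured. Compound 3 `N#Cc1ccc(-c2nc(C(c3ccc(F)cc3)c3ccc(F)cc3)sc2CC(=O)O)cc1` gives 150 nM and stands at the highest number of the three, though its difference from compound 1 `NS(=O)(=O)c1cccc(-c2nc(C(c3ccc(F)cc3)c3ccc(F)cc3)sc2CC(=O)O)c1`, which gives 140 nM, is a 1.1-fold higher number from compound 1 to compound 3 (0.03 log units; within the scatter). Going by the values given here, the one outlier is compound 2 `O=C(O)Cc1sc(C(c2ccc(F)cc2)c2ccc(F)cc2)nc1-c1ccnc(Cl)c1`, which gives 3.1 nM; its step to compound 3 is a 48-fold higher number from compound 2 to compound 3 (1.68 log units; beyond the scatter), and the step from compound 1 is a 45-fold lower number from compound 1 to compound 2 (1.65 log units; beyond the scatter).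

The step now followed leads from compound 3 to compound 4 `CN(C)c1cc(-c2nc(C(c3ccc(F)cc3)c3ccc(F)cc3)sc2CC(=O)O)ccn1`, where the change is 2-(dimethylamino)pyridin-4-yl in place of 4-cyanophenyl on an aromatic carbon. Among the compounds with values here, this change brings back the pyridin-4-yl ring with a group on it that compound 2 carries, so the step that bears most directly on it is the one between compound 2 and compound 3, with compound 2 far lower. The group on the pyridine is not the same, so the gain in compound 4 may not reach all the way to compound 2. In this assay the step from compound 3 to compound 4 is therefore expected to be a 19-fold lower number from compound 3 to compound 4 (1.27 log units; beyond the scatter), a large fall in the number. Compound 4 is thus estimated to give 8 nM in this assay, with a range from 2 nM to 40 nM.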

Compound 4, half-maximal inhibitory concentration: 380 nM
Compound 4: the middle estimate sits 48-fold (1.68 log units) below what was measured, and the stated range ends below it.
By their numbers in this assay, from the lowest: compound 2; then compounds 1 and 3 (each within the scatter of the next); then compound 4.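

In this assay, going by these compounds alone, the pyridin-4-yl ring does not by itself bring a low number: with dimethylamino in place of chloro as the only change, the step is a 120-fold higher number from compound 2 to compound 4 (2.09 log units; beyond the scatter), which makes the group on that ring decisive in this pair. Compound 4 also falls short of both phenyl analogues, with a 2.5-fold higher number from compound 3 to compound 4 (0.40 log units; beyond the scatter) and a 2.7-fold higher number from compound 1 to compound 4 (0.43 log units; beyond the scatter), so among these four compounds it is the weakest inhibitor, and a pyridine carrying a group at this place can lie on either side of the phenyl analogues, with compound 2 far lower and compound 4 higher. No measurement given here accounts for the distance between chloro and dimethylamino on this ring.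

On these data alone, with only these two groups on the pyridine, it remains open whether the low number of compound 2 is particular to chloro or would also be seen with fluoro, bromo or methyl on the same carbon. As far as these compounds go, it is equally open where a smaller nitrogen group, such as a primary amine or methylamino, or a methoxy group, would fall between compound 2 and compound 4.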